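A few compounds are considered here, and "the series" means these few. Any claim that something is new, unique, unknown or untested is made for them only; others in the source may bear on it.

Measured compounds in an assay for inhibition of serine/threonine-protein kinase Sgk1 (Homo sapiens), with stated times of 30 min and 60 min, in the presence of a further agent that is not named here; on this read-out higher numbers stand for weaker inhibition and lower numbers for stronger inhibition:
- compound 1, `Cc1n[nH]c2nc(-c3ccc(NS(=O)(=O)c4cc(Cl)ccc4F)cc3)nc(OCC3(CN)COC3)c12`, gives 1 nM
- compound 2, `Cc1n[nH]c2nc(-c3ccc(NS(=O)(=O)c4cc(Cl)ccc4F)cc3)nc(OCCCO)c12`, gives 2 nM

Compound 2 holds the highest of the two numbers in this assay; its nearest neighbour is compound 1, and the step of a 2.0-fold higher number from compound 1 to compound 2 (0.30 log units; within the scatter) lies within the scatter, so no order between the two is claimed.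

Compound 3, `CCN1CCCC(Oc2nc(-c3ccc(NS(=O)(=O)c4cc(Cl)ccc4F)cc3)nc3[nH]nc(C)c23)C1`, is not yet measured. The change from compound 2 is 1-ethylpiperidin-3-yl in place of 3-hydroxypropyl on an oxygen on an aromatic ring. Going by the values given here, only one measured step touches this position: a 2.0-fold higher number from compound 1 to compound 2 (0.30 log units; within the scatter), which exchanged one substituent for another on the same oxygen and moved the number only within the scatter. Among the compounds with values here, that single step suggests the group on this oxygen can vary without a large effect, but it involved a different pair of groups and no measured compound carries a six-membered non-aromatic ring here, so the evidence is thin. The step of a 1.3-fold higher number from compound 2 to compound 3 (0.10 log units; within the scatter) is therefore expected to stay within the scatter. Compound 3 is estimated at 2.5 nM, with a range from 0.6 nM to 10 nM.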

Compound 3, half-maximal inhibitory concentration: 6 nM
The estimate for compound 3 lay 2.4-fold (0.38 log units) below the measured number; low and high end bracket the measured number.
By their numbers in this assay, from the lowest: compounds 1 and 2 (each within the scatter of the next); then compound 3.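

In this assay, the group on the oxygen on an aromatic ring now gives steps beyond the scatter: 1-ethylpiperidin-3-yl in place of 3-hydroxypropyl gives a 3.0-fold higher number from compound 2 to compound 3 (0.48 log units; beyond the scatter), and the same group in place of (3-(aminomethyl)oxetan-3-yl)methyl gives a 6.0-fold higher number from compound 1 to compound 3 (0.78 log units; beyond the scatter). The earlier exchange at this oxygen, a 2.0-fold higher number from compound 1 to compound 2 (0.30 log units; within the scatter), stayed within the scatter, so the position is not indifferent to every group, although both new steps are modest and compound 3 still gives 6 nM with a six-membered non-aromatic ring in this place. No measurement at hand accounts for the higher number of compound 3.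

The change from 3-hydroxypropyl alters several things at once, bringing in a ring and an ethyl-bearing ring nitrogen and removing a hydroxyl, and the compounds shown cannot separate these parts. Still open, from the compounds shown here alone, are how a piperidin-3-yl without the ethyl, a tetrahydropyran-3-yl with oxygen in place of the ring nitrogen, or a longer open chain ending in a tertiary amine would compare with compound 3 in this assay.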